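The compounds below may be only part of what the source reports. "The series", "measured", "known", "first", "only" and "open" are said of these compounds alone.

Going by the values given here, compound 2 `CS(=O)(=O)Nc1cccc(-c2nc(C(c3ccc(F)cc3)c3ccc(F)cc3)sc2CC(=O)O)c1` gives 370 nM in an in vitro functional assay on HEK285-7 cells for antagonist activity at prostaglandin D2 receptor 2 (Homo sapiens), read by BRET and beta-arrestin recruitment; on this read-out higher numbers stand for weaker inhibition and lower numbers for stronger inhibition; of the two numbers so far, it cannot be told apart from compound 1 `O=C(O)Cc1sc(C(c2ccc(F)cc2)c2ccc(F)cc2)nc1-c1cc(F)cc(F)c1`, which gives 340 nM. Among the compounds with values here, the one measured step at this position, a 1.1-fold higher number from compound 1 to compound 2 (0.04 log units; within the scatter), stayed within the scatter. Compound 3 `Cc1cc(-c2nc(C(c3ccc(F)cc3)c3ccc(F)cc3)sc2CC(=O)O)ccn1` differs from compound 2 by 2-methylpyridin-4-yl in place of 3-(methanesulfonamido)phenyl on an aromatic carbon. Since that single step, a 1.1-fold higher number from compound 1 to compound 2 (0.04 log units; within the scatter), was so small, a step of a 1.1-fold higher number from compound 2 to compound 3 (0.03 log units; within the scatter) is expected from compound 2 to compound 3, none beyond the scatter. Compound 3 is therefore estimated at 400 nM, in the range 150 nM to 1100 nM.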

Compound 3, half-maximal inhibitory concentration: 53 nM
Beside the measured number, compound 3's estimate is 7.5-fold (0.88 log units) above it, outside the stated range (below it).
By their numbers in this assay, from the lowest: compound 3; then compounds 1 and 2 (each within the scatter of the next).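

In this assay this position, on the aromatic carbon next to the ring nitrogen, proves sensitive to the group it carries, with 2-methylpyridin-4-yl giving a 7.0-fold lower number from compound 2 to compound 3 (0.84 log units; beyond the scatter) and also a 6.4-fold lower number from compound 1 to compound 3 (0.81 log units; beyond the scatter) in place of 3,5-difluorophenyl. The position is therefore not indifferent to its substituent, as the two substituted phenyl groups alone had suggested. No evidence at hand explains this gain. A pyridin-4-yl without the methyl group, or a 3-methylphenyl group, would show whether the ring nitrogen or the methyl group carries the step.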